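A few compounds are considered here, and "the series" means these few. Any claim that something is new, unique, unknown or untested is made for them only; others in the source may bear on it.

Compound 1, `Cc1cccc(C)c1-c1cccc(COc2ccc(S(=O)(=O)CC(=O)O)cc2)c1`, gives 66.1 nM in a functional assay on CHO cells for agonist activity at Free fatty acid receptor 1 (Homo sapiens), read by FLIPR and calcium flux; on this read-out higher numbers stand for an effect only at larger amounts of compound and lower numbers for an effect already at smaller amounts.
Compound 2, `COc1cc(C)c(-c2cccc(COc3ccc4c(c3)SCC4CC(=O)O)c2)c(C)c1`, gives 123 nM in this assay.
Compound 3, `COc1cc(C)c(-c2cccc(COc3ccc4c(c3)C(=O)CC4CC(=O)O)c2)c(C)c1`, gives 234 nM in this assay.

Three compounds share a biaryl built on a dimethylphenyl ring joined through a benzyl ether to an acid-bearing aryl group; they differ in the acid head and in whether the dimethylphenyl ring carries a methoxy group. Among the three numbers, compound 1 gives the lowest. The gap between compound 1 and compound 2 is within the scatter, so nothing can be said about their order. Compound 3 gives a clearly higher number than compound 1, beyond the scatter.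

Compound 4, `CCCOc1cc(C)c(-c2cccc(COc3ccc(S(=O)(=O)CC(=O)O)cc3)c2)c(C)c1`, has not yet been measured. It keeps the whole of compound 1 and adds one group: propoxy in place of hydrogen on an aromatic carbon. Among the measured compounds shown here, compounds 2 and 3 both carry a methoxy on the corresponding position of their dimethylphenyl ring, but each also differs from compound 1 in the acid head, so no single-change step toward compound 4 exists among the measured compounds. In this assay a step from compound 1 to compound 4 of about a 1.7-fold lower number from compound 1 to compound 4 (0.22 log units; within the scatter) is expected, toward a lower number, but not certainly beyond the scatter. Compound 4 is therefore estimated at 40 nM, with a likely range from 12 nM to 130 nM.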

Compound 4, half-maximal effective concentration: 69.2 nM
The estimate for compound 4 lay 1.7-fold (0.24 log units) below the measured number, within the range that was stated.
By their numbers in this assay, from the lowest: compounds 1, 4, 2 and 3 (each within the scatter of the next, the first and the last beyond it).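

Among the compounds shown here, replacing hydrogen with propoxy on this aromatic carbon, meta to two methyl groups and para to a large group, gives in this assay a step of a 1.0-fold higher number from compound 1 to compound 4 (0.02 log units; within the scatter) and is the first single change at this position that can be read, since compound 2 and compound 3 also differ from compound 1 in the acid head. Adding a chain of 4 heavy atoms here therefore leaves compound 1 and compound 4 indistinguishable on this read-out, so at least on this acid head the position accepts propoxy without a detectable change in either direction. No measurement is available that would explain this result.

The compounds shown leave open whether a hydroxyl group, an amine or a longer chain such as hexyloxy at this carbon would also leave the number unchanged, and whether methoxy would match propoxy on the core of compound 1. They also leave open whether propoxy would give the same flat step on the other acid heads, as this single pair speaks for one head only.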